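The compounds below may be only part of what the source reports. "The series", "measured", "known", "first", "only" and "open" are said of these compounds alone.

Of the compounds shown here, two have so far been measured in an ADME assay on S9 fraction from liver (Rattus norvegicus) for metabolic stability, read by LC-MS, using NADPH, with a stated time of 30 min; on this read-out lower numbers stand for a less stable compound and higher numbers for a more stable compound. Compound 2, `CCCCCCCCc1ccc(OCC(=O)Cn2nnnc2-c2ccccc2)cc1`, gives 36% in this assay, the only number shown so far. Compound 1, `CCCCCCCCc1ccc(OCC(=O)Cn2nnc(CCC(=O)O)n2)cc1`, reaches only a limit of this assay, < 5%, which is a limit and not a number (the limit of < 5% in this assay, at which 1 of the 2 values shown sits). Compound 3, `CCCCCCCCc1ccc(OCC(=O)Cn2nnnc2-c2cccc(C(=O)O)c2)cc1`, is not yet measured and differs from compound 2 by carboxy in place of hydrogen on an aromatic carbon. For the measured compounds named here, with no measured step between compounds available, the step is expected to be a number 16 percentage points lower from compound 2 to compound 3 (beyond the scatter), a decrease somewhat beyond the scatter. Compound 3 is therefore estimated to give 20%, between 5% and 45%.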

Compound 3, percent of the compound remaining: < 5%
Compound 3 ended at the assay's limit; the forecaster's own chance of this, stated with the estimate: 20%; at least 15 percentage points between middle value and limit.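

For the compounds shown here, this is the first step that can be read: in this assay, carboxy in place of hydrogen on an aromatic carbon, meta to a large group, gives a number at least 31 percentage points lower from compound 2 to compound 3 (beyond the scatter). A single change on the phenyl ring is thus enough to lose the measurable number that compound 2 holds. The value of compound 3, < 5%, is a limit and not a number: the limit of < 5% in this assay, at which 2 of the 3 values shown sit.

From the compounds shown here alone, what a methyl ester or a primary amide would give in place of the carboxy group stays open. Going by these compounds, whether the step holds on another core also stays open.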